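A few compounds are considered here, and "the series" means these few. Any claim that something is new, unique, unknown or untested is made for them only; others in the source may bear on it.

Measured compounds in a functional assay on HeLa cells (Homo sapiens) for cytotoxicity, read by MTT assay; on this read-out lower numbers stand for stronger inhibition and higher numbers for weaker inhibition:
Compound 1, `CC(C)=CC[C@@H](OC(=O)c1ccoc1)C1=CC(=O)c2c(O)ccc(O)c2C1=O`, stands at a limit of the assay, > 100000 nM.
Compound 2, `CC[C@@](C)(O)CC(=O)O[C@H](CC=C(C)C)C1=CC(=O)c2c(O)ccc(O)c2C1=O`, gives 17900 nM.
Compound 3, `CCCC(CC(=O)O[C@H](CC=C(C)C)C1=CC(=O)c2c(O)ccc(O)c2C1=O)OC(C)=O`, gives 51200 nM.

Within the data shown here, compound 3 holds the highest of the two numbers known in this assay; the only other number is reached by a 2.9-fold higher number from compound 2 to compound 3 (0.46 log units; beyond the scatter). Compound 1 sits at a limit and contributes no number (the limit of > 100000 nM in this assay, at which 1 of the 3 values shown sits).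

Compound 4, `CCCCC(CC(=O)O[C@H](CC=C(C)C)C1=CC(=O)c2c(O)ccc(O)c2C1=O)OC(C)=O`, differs from compound 3 by methyl in place of hydrogen on a saturated chain carbon, four bonds along the chain from an oxygen next to a carbonyl group; cut one bond further out, the change reads propyl to butyl. Among the measured compounds shown here, none of the measured steps bears directly on it. The steps of an at least 5.5-fold lower number from compound 1 to compound 2 (0.74 log units; beyond the scatter) and an at least 1.9-fold lower number from compound 1 to compound 3 (0.29 log units; that floor lies within the scatter) exchange whole groups on the carbonyl carbon, and the step of a 2.9-fold higher number from compound 2 to compound 3 (0.46 log units; beyond the scatter) swaps the substituent on the chain carbon bound to the carbonyl carbon; none of them adds a methyl along an otherwise unchanged chain. The expected step is therefore none beyond the scatter, a 1.0-fold lower number from compound 3 to compound 4 (0.01 log units; within the scatter). Compound 4 is estimated at 50000 nM, expected to fall between 20000 nM and 120000 nM.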

Compound 4, half-maximal inhibitory concentration: 73500 nM
Beside the measured number, compound 4's estimate is 1.5-fold (0.17 log units) below it; the range from low to high includes it.
By their numbers in this assay, from the lowest: compound 2; then compounds 3 and 4 (each within the scatter of the next). At a limit, above all of these: compound 1.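

In this assay, the change from propyl to butyl, methyl in place of hydrogen on a saturated chain carbon, four bonds along the chain from an oxygen next to a carbonyl group, gives a 1.4-fold higher number from compound 3 to compound 4 (0.16 log units; within the scatter), so this extension cannot be told from the scatter. The step measured against the hydroxy compound, a 4.1-fold higher number from compound 2 to compound 4 (0.61 log units; beyond the scatter), stays beyond the scatter, as the corresponding step to the propyl compound did. The remaining step, an at least 1.3-fold lower number from compound 1 to compound 4 (0.13 log units; that floor lies within the scatter), gives only a floor. Compound 1 stands at a limit and gives no number: the limit of > 100000 nM in this assay, at which 1 of the 4 values shown sits.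

The compounds shown leave open whether a longer chain, such as hexyl or octyl, would move the number beyond the scatter. They also leave open what a terminal amine or carboxylic acid on this chain would do.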